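Alkoxy chain size and growth inhibition in a chalcone series

The source may hold more compounds than are shown below. What is called first, only, known or untested is meant among the compounds shown, and "the series" means these compounds.

Measured so far:
compound 1 `O=C(/C=C/c1ccc(O)cc1)c1c(O)cccc1OCC1CCCCC1`: > 30000 nM
compound 2 `CC(C)CCOc1cccc(O)c1C(=O)/C=C/c1ccc(O)cc1`: 10600 nM
compound 3 `CC(C)COc1cccc(O)c1C(=O)/C=C/c1ccc(O)cc1`: 2600 nM

In a functional assay on HCT-15 cells (Homo sapiens) for antiproliferative activity, read by sulforhodamine B assay (on this read-out higher numbers stand for weaker inhibition of growth and lower numbers for stronger inhibition of growth), compound 1 sits at a limit of the assay rather than at a number, the limit of the limit of > 30000 nM in this assay, at which 1 of the 3 values shown sits. Compound 4 `CCCCOc1cccc(O)c1C(=O)/C=C/c1ccc(O)cc1` differs from compound 1 thus: propyl in place of cyclohexyl on a saturated chain carbon bound to an oxygen on an aromatic ring. Going by the values given here, the steps that bear on it are an at least 2.8-fold lower number from compound 1 to compound 2 (0.45 log units; beyond the scatter) and an at least 11-fold lower number from compound 1 to compound 3 (1.06 log units; beyond the scatter), with the smaller alkyl giving the larger drop; between those two, a 4.1-fold lower number from compound 2 to compound 3 (0.61 log units; beyond the scatter). Propyl is a chain of the same count as isopropyl, so a drop of at least modest size in this assay is expected, most likely a number between those of compound 2 and compound 3. For compound 4 the estimate is 4500 nM, from 1500 nM to 13000 nM, which is expected to mean an at least 6.6-fold lower number from compound 1 to compound 4 (0.82 log units; beyond the scatter).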

Compound 4, concentration for 50% growth inhibition: > 30000 nM
Compound 4: a limit, no number (the forecaster's own chance of this, stated with the estimate: 5%); middle value at least 6.6-fold (0.82 log units) away from the limit.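

In this assay compound 4 gives a limit, not a number: the limit of > 30000 nM in this assay, at which 2 of the 4 values shown sit.

Putting propyl in place of isopropyl gives an at least 11-fold higher number from compound 3 to compound 4 (1.06 log units; beyond the scatter), and removing the methyl from the chain of compound 2 gives an at least 2.8-fold higher number from compound 2 to compound 4 (0.45 log units; beyond the scatter). Among compounds 2, 3 and 4, growth inhibition that reads as a number therefore appears only with the branched chains, and the smaller size of propyl relative to cyclohexyl brings no readable gain, as the two limits leave the step between compound 1 and compound 4 unreadable.

Open, as far as these compounds go, is whether a longer straight chain such as hexyl also stays at the limit. Also open, from the compounds shown here alone, is whether an amine at the chain end changes the read-out.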